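A few compounds are considered here, and "the series" means these few. Any claim that something is new, unique, unknown or untested is made for them only; others in the source may bear on it.

Compound 1 `CCOC(=O)N1CCN(Cc2c(O)c([C@H]3CCN(C)C[C@H]3O)c3oc(C)cc(=O)c3c2O)CC1` and compound 2 `Cc1oc2c([C@H]3CCN(C)C[C@H]3O)c(O)cc(O)c2c(=O)c1C(O)c1ccc(Cl)cc1` share the same core and were both tested in a functional assay on HL-60 cells (Homo sapiens) for inhibition, read by MTT assay, with a stated time of 48 h, tested at 10 uM; on this read-out higher numbers stand for more inhibition of growth at the one concentration tested and lower numbers for less inhibition of growth. In this assay compound 1 gives 16%, and compound 2 gives 2%, the lower of the two numbers, sitting beyond the scatter below compound 1. Compound 3 `Cc1oc2c([C@H]3CCN(C)C[C@H]3O)c(O)cc(O)c2c(=O)c1C(O)c1cc(F)cc(F)c1` differs from compound 2 in one place only: 3,5-difluorophenyl in place of 4-chlorophenyl on a saturated chain carbon bound to an aromatic carbon and an oxygen on a saturated carbon. Among the measured compounds shown here, no step between two measured compounds matches this change, so there is nothing to scale from. For compound 3 a step of a number 3 percentage points higher from compound 2 to compound 3 (within the scatter) is expected, which is none beyond the scatter. Compound 3 is therefore estimated at 5%, with a range from -10% to 22%.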

Compound 3, percent growth inhibition at one concentration: 30%
Compound 3: the middle estimate sits 25 percentage points below what was measured, outside the stated range (above it).
By their numbers in this assay, from the lowest: compound 2; then compound 1; then compound 3.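

In this assay, going from (4-chlorophenyl)(hydroxy)methyl to (3,5-difluorophenyl)(hydroxy)methyl gives a number 28 percentage points higher from compound 2 to compound 3 (beyond the scatter). This shows that growth inhibition at this position responds to which halogens the phenyl ring carries and where they sit, even though both rings count no hydrogen-bond donors or acceptors. Nothing measured here accounts for the step. Still open, going by these compounds, is whether the halogen or its ring position matters more, which a 4-fluorophenyl or 3,5-dichlorophenyl group could help separate. Also open, on these data alone, is how an unsubstituted phenyl group would compare.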